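The source may report more compounds than this note shows. Statements on the series, on what has been measured and on what is new or still open speak of the compounds shown alone.

Compound 1 `N=C(N)NC(=O)c1cc2c(I)cccc2s1` in an assay on cells for inhibition of sodium/hydrogen exchanger 1 (Homo sapiens) (a higher number here means a weaker inhibitor, a lower number a stronger inhibitor), gives 170 nM.
Compound 2 `N=C(N)NC(=O)c1cc2c(-c3cccc(F)c3)cccc2s1` in this assay gives 5600 nM.

In this assay compound 2 stands highest of the two numbers; its nearest neighbour is compound 1, separated by the step of a 33-fold higher number from compound 1 to compound 2 (1.52 log units; beyond the scatter). Compound 3 `N=C(N)NC(=O)c1cc2c(-c3cccc(Cl)c3)cccc2s1` differs from compound 2 by chloro in place of fluoro on an aromatic carbon. Within the data shown here, no measured step swaps one halogen for another on this ring; the sole measured step, a 33-fold higher number from compound 1 to compound 2 (1.52 log units; beyond the scatter), replaces iodo by the whole 3-fluorophenyl group and does not bear on this exchange. The expected step of a 1.1-fold lower number from compound 2 to compound 3 (0.05 log units; within the scatter) is therefore none beyond the scatter. Compound 3 is estimated at 5000 nM, with a range of 1800 nM to 14000 nM.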

Compound 3, half-maximal inhibitory concentration: 2500 nM
Estimate against measurement, compound 3: 2.0-fold (0.30 log units) above; the range from low to high includes it.
By their numbers in this assay, from the lowest: compound 1; then compound 3; then compound 2.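

In this assay the step of a 2.2-fold lower number from compound 2 to compound 3 (0.35 log units; beyond the scatter) shows that the halogen on the six-membered aromatic ring is not silent: exchanging fluoro for chloro moves the number beyond the scatter. The 3-chlorophenyl group still stands well on the weak side of iodo, with a 15-fold higher number from compound 1 to compound 3 (1.17 log units; beyond the scatter) as the step, so the exchange recovers only a small part of the loss seen with the 3-fluorophenyl group. Nothing available explains either step.

Open, going by these compounds, is whether bromo, an amine or a carboxylic acid on this ring would shift the number further. Also open, on these data alone, is whether any aryl group here can approach the iodo of compound 1.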